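Swapping One Small Aromatic Ring for Another

This account rests on a few compounds, and the source may have more. Where it says the series, first, only, none or still open, it means among the compounds named here.

Measured so far:
compound 1 `CC(C)C(Nc1nccs1)c1ccc(-c2ccc3cccc(F)c3c2)[nH]c1=O`: 9.4 nM
compound 2 `CCn1ncc2c(F)cc(-c3ccc(C(CC)(CC)c4ncn(C)n4)c(=O)[nH]3)cc21`: 39 nM
compound 3 `CC(C)C(c1noc(=O)[nH]1)c1ccc(-c2ccc3cccc(F)c3c2)[nH]c1=O`: 15 nM

In an assay on CHO cells for displacement of a labelled ligand from prostaglandin E2 receptor EP3 subtype (Homo sapiens), read by radioligand binding (a lower number here means a stronger inhibitor, a higher number a weaker inhibitor), compound 3 gives 15 nM. That number lies within the scatter of compound 1, and it is lower than the number of compound 2, a gap beyond the scatter. Compound 4 `CC(C)C(Nc1nnc[nH]1)c1ccc(-c2ccc3cccc(F)c3c2)[nH]c1=O` differs from compound 3 in one place: a group of 6 heavy atoms (2 carbon, 4 nitrogen; one five-membered aromatic ring with 3 hetero atoms) in place of a group of 6 heavy atoms (2 carbon, 2 nitrogen, 2 oxygen; one five-membered aromatic ring with 3 hetero atoms), on a saturated chain carbon bound to an aromatic carbon and a saturated chain carbon. For the measured compounds named here, the only measured step that bears on this is a 1.6-fold higher number from compound 1 to compound 3 (0.20 log units; within the scatter), in which a ring carried on an amino group gave way to a ring attached directly, with no change beyond the scatter. Compound 4 returns to a ring carried on an amino group, the (4H-1,2,4-triazol-3-yl)amino group. The expected step is therefore small, a 1.3-fold lower number from compound 3 to compound 4 (0.10 log units; within the scatter). Compound 4 is estimated at 12 nM, within a range of 4 nM to 40 nM.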

Compound 4, inhibition constant: 22 nM
For compound 4 the middle estimate is 1.8-fold (0.26 log units) below the measured one; measured number inside the range.
By their numbers in this assay, from the lowest: compounds 1, 3, 4 and 2 (each within the scatter of the next, the first and the last beyond it).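

In this assay the move a 1.5-fold higher number from compound 3 to compound 4 (0.17 log units; within the scatter) shows that this saturated chain carbon carries the (4H-1,2,4-triazol-3-yl)amino group and the directly attached ring about equally well. The ring on the amine nitrogen still matters modestly: 4H-1,2,4-triazol-3-yl in place of 1,3-thiazol-2-yl gives a 2.3-fold higher number from compound 1 to compound 4 (0.37 log units; beyond the scatter) as the first difference beyond the scatter between two such rings. Going by these compounds, whether a carboxylic acid or a plain amine on this carbon would stay in the same range remains open. No measurement here offers an explanation for either step.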